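Cyclopropyl in place of methyl on the carbonyl of compound 3

The compounds below may be only part of what the source reports. "The series", "measured", "known", "first", "only" and "open" are said of these compounds alone.

The series shares one core carrying a carbonyl substituent and a five-membered aromatic ring. In an assay on membranes from CHO cells for displacement of a labelled ligand from adenosine receptor A1 (Homo sapiens), read by scintillation counting, with a stated time of 60 min, tested at 1 uM (on this read-out lower numbers stand for less inhibition and higher numbers for more inhibition at the one concentration tested (going by the name of the read-out)), compound 1 `CCCOC(=O)C1=C(C)NC(=O)NC1c1ccsc1` gives 44%, compound 2 `CC1=C(C(=O)C2CC2)C(c2ccoc2)NC(=O)N1` gives 1%, and compound 3 `CC(=O)C1=C(C)NC(=O)NC1c1ccsc1` gives 9%. Compound 3 thus stands second highest of the three, its value within the scatter of that of compound 2 and well below compound 1, as the step of a number 35 percentage points lower from compound 1 to compound 3 (beyond the scatter) shows. Compound 4 `CC1=C(C(=O)C2CC2)C(c2ccsc2)NC(=O)N1` differs from compound 3 by cyclopropyl in place of methyl on a carbonyl carbon. For the measured compounds named here, no measured step matches this change; the one step known alters the carbonyl substituent differently. Compound 2 already carries the cyclopropylcarbonyl, on a furan, and its value sits within the scatter of compound 3. For compound 4 a step of a number 3 percentage points lower from compound 3 to compound 4 (within the scatter) is therefore expected, none beyond the scatter, and its value is estimated at 6%, between -8% and 22%.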

Compound 4, a percentage reported as inhibition, at one concentration (the size of the read-out at that concentration, not a potency): 2%
Estimate against measurement, compound 4: 4 percentage points above; measured number inside the range.
By their numbers in this assay, from the lowest: compounds 2, 4 and 3 (each within the scatter of the next); then compound 1.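

In this assay, cyclopropyl on the carbonyl carbon gives a number 7 percentage points lower from compound 3 to compound 4 (within the scatter) and so does not separate itself from methyl on the thiophen-3-yl compounds. Thiophen-3-yl in place of furan-3-yl gives a number 1 percentage points higher from compound 2 to compound 4 (within the scatter) and shows that, with cyclopropylcarbonyl in place, these two rings cannot be told apart here. Against propoxy, cyclopropyl gives a number 42 percentage points lower from compound 1 to compound 4 (beyond the scatter) as the step, so of the three groups on this carbonyl carbon only propoxy stands apart. On these data alone, whether butoxy or an amine on this carbon would match propoxy remains open. Why propoxy stands apart also remains open, as no evidence on it is at hand.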